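The source may hold more compounds than are shown below. What is called first, only, known or untested is meant among the compounds shown, and "the series" means these compounds.

Among the measured compounds shown here, in a functional assay on KB cells (Homo sapiens) for antiproliferative activity, read by sulforhodamine B assay, with a stated time of 72 h (a higher number here means a weaker inhibitor of growth, a lower number a stronger inhibitor of growth), compound 3 `CCOc1ccc2c(=O)cc(C(C)Br)oc2c1CBr` gives 15600 nM, one of only two plain numbers available; the other belongs to compound 2 `COc1ccc2c(=O)cc(C(C)Br)oc2c1CBr` at 15100 nM, and the two lie within the scatter of each other. Compound 1 `CCc1cc(=O)c2ccc(OC(C)C)c(CBr)c2o1` gives no number but a limit of the assay, > 30700 nM. Compound 4 `CC(C)Oc1ccc2c(=O)cc(C(C)Br)oc2c1CBr` differs from compound 3 by methyl in place of hydrogen on a saturated chain carbon bound to an oxygen on an aromatic ring and a saturated chain carbon. For the measured compounds named here, the single measured step of the same kind, a 1.0-fold higher number from compound 2 to compound 3 (0.01 log units; within the scatter), changed nothing beyond the scatter. On that basis the expected step in this assay is a 1.0-fold higher number from compound 3 to compound 4 (0.01 log units; within the scatter), that is, no change beyond the scatter. Compound 4 is therefore estimated at 16000 nM in this assay, with a likely range from 7000 nM to 36000 nM.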

Compound 4, concentration for 50% growth inhibition: 12800 nM
Compound 4: the middle estimate sits 1.3-fold (0.10 log units) above what was measured; the measured number falls inside the stated range.
By their numbers in this assay, from the lowest: compounds 4, 2 and 3 (each within the scatter of the next). At a limit, above all of these: compound 1.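

In this assay the chain on this oxygen can grow further without moving the number: ethyl to isopropyl gives a 1.2-fold lower number from compound 3 to compound 4 (0.09 log units; within the scatter) and methyl to isopropyl gives a 1.2-fold lower number from compound 2 to compound 4 (0.07 log units; within the scatter), so all three chains read alike on this core. Among the compounds shown here, the only step beyond the scatter is an at least 2.3-fold lower number from compound 1 to compound 4 (0.37 log units; beyond the scatter) and it comes with bromo in place of hydrogen on the saturated chain carbon. Compound 1 gives only a limit, so this step has no exact size: the limit of > 30700 nM in this assay, at which 1 of the 4 values shown sits.

From the compounds shown here alone, whether a longer chain, an amine or a carboxylic acid on this oxygen would shift the number remains open.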